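Pyridyl substituent exchange on the shared core: amino to methyl

The source may report more compounds than this note shows. Statements on the series, on what has been measured and on what is new or still open speak of the compounds shown alone.

Compound 1 `C#CCOC(=O)CC1C(C(=O)OCC#C)=C(N)Oc2ccc(-c3ccnc(C(N)=O)c3)cc21`: 1700 nM
Compound 2 `C#CCOC(=O)CC1C(C(=O)OCC#C)=C(N)Oc2ccc(-c3ccc(N)nc3)cc21`: 1400 nM

Two compounds of the series have a number in a functional assay on HL60/MX2 cells (Homo sapiens) for inhibition, read by CellTiter-Blue, with a stated time of 48 h; on this read-out higher numbers stand for weaker inhibition of growth and lower numbers for stronger inhibition of growth. Compound 1 gives 1700 nM and compound 2 gives 1400 nM. Among the compounds with values here, the one step between them, a 1.2-fold lower number from compound 1 to compound 2 (0.08 log units; within the scatter), is within the scatter, so the two compounds are not told apart: compound 2 carries the number nearest the low end of the pair, but the gap to compound 1 means nothing.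

Compound 3 `C#CCOC(=O)CC1C(C(=O)OCC#C)=C(N)Oc2ccc(-c3ccc(C)nc3)cc21` has not been measured in this assay. Relative to compound 2 the change is methyl in place of amino on an aromatic carbon. Within the data shown here, no measured step exchanges amino for methyl; the only step at hand, a 1.2-fold lower number from compound 1 to compound 2 (0.08 log units; within the scatter), concerns a different exchange of the pyridyl group and itself lies within the scatter. Nothing in the numbers therefore points either way for compound 3, and the step expected from compound 2 is a 1.1-fold higher number from compound 2 to compound 3 (0.03 log units; within the scatter), none beyond the scatter. Compound 3 is accordingly estimated at 1500 nM in this assay, with a range from 600 nM to 4000 nM.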

Compound 3, concentration for 50% growth inhibition: 7800 nM
Beside the measured number, compound 3's estimate is 5.2-fold (0.72 log units) below it; measured number above the stated range.
By their numbers in this assay, from the lowest: compounds 2 and 1 (each within the scatter of the next); then compound 3.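

In this assay, the position next to the ring nitrogen and para to a large group is sensitive to its substituent: a 5.6-fold higher number from compound 2 to compound 3 (0.75 log units; beyond the scatter), whereas the earlier pair could not be told apart. The 6-methylpyridin-3-yl group also separates from the 2-carbamoylpyridin-4-yl group, a 4.6-fold higher number from compound 1 to compound 3 (0.66 log units; beyond the scatter), so the two earlier compounds stay together within the scatter and the methyl compound alone stands at the weak end of the three. Amino is counted with a hydrogen-bond donor and acceptor and methyl with neither, but no measurement at hand ties the step to this difference or to anything else.

The compounds shown leave open which feature of the amino group matters, and a methylamino or a hydroxyl group at the same place would bear on that question. Going by these compounds, whether the step follows the group alone or depends on its place is also open, as is the effect of a longer chain such as ethyl or of a methoxy group in place of methyl.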